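The compounds below may be only part of what the source reports. "The series", "measured", "known", "first", "only" and "open" are said of these compounds alone.

Working notes on the series.

Compound 1 `CN1CCN(c2nc3cc([N+](=O)[O-])ccc3o2)CC1` is the reference point here. Among the compounds with values here, in an assay on ileum (strain Hartley) with 5-hydroxytryptamine receptor 3A (Cavia porcellus) as the target (a lower number here means a smaller maximal response, a higher number a larger maximal response), compound 1 gives 0.52, the higher of the two numbers known so far. Compound 2 `CCc1cc(C)cc2nc(N3CCN(C)CC3)oc12` gives 0.26 in this assay, a number that falls below that of compound 1 by more than the usual scatter, so the two values are distinguishable. No single-point change connects compound 1 and compound 2, so nothing is said about a step between them beyond what the two values show.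

Compound 3 `CN1CCN(c2nc3cc(N)ccc3o2)CC1` has not yet been measured in this assay. Against compound 1 it differs in one place: amino in place of nitro on an aromatic carbon

With no measured pair of this kind in the series, the size of the step can only be judged loosely. The values of compound 1 and compound 2 show that changes on the carbon ring move the maximal response, so a change beyond the scatter, most likely downward, is expected. The expected step from compound 1 to compound 3 is a number 0.12 lower from compound 1 to compound 3 (beyond the scatter). Compound 3 is therefore estimated at 0.4, with a range from 0.15 to 0.7.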

Compound 3, intrinsic activity: the largest response reached, as a fraction of the reference agonist's: 0.76
The estimate for compound 3 lay 0.36 below the measured number, outside the stated range (above it).
By their numbers in this assay, from the lowest: compound 2; then compound 1; then compound 3.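

Amino in place of nitro on an aromatic carbon gives a number 0.24 higher from compound 1 to compound 3 (beyond the scatter) in this assay, so this carbon of the shared core is a place where a single substitution shifts the maximal response in a readable way. The nitro group is therefore not required for a response here, and in this one pair the larger maximal response goes with the amino group, which brings a hydrogen-bond donor and fewer heavy atoms to the same carbon. No measurement at hand ties this step to any particular feature of the exchange.

A single pair cannot separate what the departure of nitro contributes from what the arrival of amino contributes, and it gives no trend across substituents at this carbon. The compounds shown leave open whether a hydroxyl group, an acetamide or a dimethylamino group on this aromatic carbon would stay with compound 3 or fall back toward compound 1 in this assay.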